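Chain terminus variation on the dithioacetal diacid series

A few compounds are considered here, and "the series" means these few. Any claim that something is new, unique, unknown or untested is made for them only; others in the source may bear on it.

For the measured compounds named here, compound 2 `O=C(O)CCSC(SCCC(=O)O)c1ccccc1CCCCCCCCC1CCCCC1` gives 1960 nM in an assay on membranes from lung (Cavia porcellus) for binding affinity to cysteinyl leukotriene receptor (Homo sapiens) (a lower number here means a stronger inhibitor, a higher number a weaker inhibitor), the highest of the two numbers measured so far; the nearest is compound 1 `CCCCCCCCCCc1ccccc1C(SCCC(=O)O)SCCC(=O)O`, which in this assay gives 1180 nM. Going by the values given here, the one measured step, a 1.7-fold higher number from compound 1 to compound 2 (0.22 log units; within the scatter), lies within the scatter. Compound 3 `C#CCCCCCCCCCCc1ccccc1C(SCCC(=O)O)SCCC(=O)O` carries but-3-yn-1-yl in place of cyclohexyl on a saturated chain carbon, eight bonds along the chain from an aromatic carbon. Among the compounds with values here, only that single step bears on this change, and it was small, so no shift beyond the scatter is expected in this assay. Compound 3 is therefore estimated at 1500 nM, within 500 nM to 4500 nM, which corresponds to an expected step of a 1.3-fold lower number from compound 2 to compound 3 (0.12 log units; within the scatter).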

Compound 3, inhibition constant: 141 nM
Beside the measured number, compound 3's estimate is 11-fold (1.03 log units) above it; the whole stated range lies above it.
By their numbers in this assay, from the lowest: compound 3; then compounds 1 and 2 (each within the scatter of the next).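

In this assay the chain end proves sensitive: while compounds 1 and 2 stay within the scatter of each other, the but-3-yn-1-yl terminus gives a 14-fold lower number from compound 2 to compound 3 (1.14 log units; beyond the scatter) and the ethynyl-for-hydrogen change gives an 8.4-fold lower number from compound 1 to compound 3 (0.92 log units; beyond the scatter) here. Compound 1 also has no cyclohexyl ring, so loss of the ring alone does not go with the lower number among these three compounds. No supporting measurement accounts for the shift. As far as these compounds go, whether it rests on the triple bond itself or on chain length remains open. A saturated chain matching that of compound 3, or a nitrile at the chain end, would separate these readings.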